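Pyrazole carboxamide series: aromatic nitrogen substituent swap

A few compounds are considered here, and "the series" means these few. Any claim that something is new, unique, unknown or untested is made for them only; others in the source may bear on it.

Measured so far:
compound 1, `Cc1c(C(=O)Nc2ccc(C(F)(F)F)cc2)cnn1Cc1ccc(F)cc1`, 3600 nM
compound 2, `Cc1c(C(=O)N(CC(=O)O)c2ccc(C(F)(F)F)cc2)cnn1-c1ccc(F)cc1`, 3200 nM
compound 3, `Cc1c(C(=O)Nc2cccc(C(F)(F)F)c2)cnn1-c1ccc(F)cc1`, 1700 nM

All three numbers come from a functional assay with Homo sapiens as the target; a lower number here means a stronger inhibitor, a higher number a weaker inhibitor. Compound 1 holds the highest number of the three. Compound 2 sits closest to it, and the gap between compound 1 and compound 2 is within the usual scatter, so no order can be read between those two. Compound 3 sits furthest from compound 1, with a number beyond the scatter below it; compounds 1 and 3 differ in more than one place, so only the two values themselves are on record.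

The next compound, compound 4, `Cc1c(C(=O)Nc2ccc(C(F)(F)F)cc2)cnn1-c1cccc(Cl)c1Cl`, differs from compound 1 in one place: 2,3-dichlorophenyl in place of 4-fluorobenzyl on an aromatic nitrogen. Going by the values given here, no step between measured compounds isolates this kind of change, so there is nothing in hand to set its size. A small step downward in this assay is expected, most likely within the scatter, though a null step cannot be excluded. For compound 4 the estimate is 2500 nM, with a range from 800 nM to 8000 nM, which would mean an expected step of a 1.4-fold lower number from compound 1 to compound 4 (0.16 log units; within the scatter).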

Compound 4, half-maximal inhibitory concentration: 1600 nM
The estimate for compound 4 lay 1.6-fold (0.19 log units) above the measured number; the measured number falls inside the stated range.
By their numbers in this assay, from the lowest: compounds 4, 3, 2 and 1 (each within the scatter of the next, the first and the last beyond it).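

In this assay, going by these compounds alone, the aromatic nitrogen position proves sensitive to its substituent: 2,3-dichlorophenyl in place of 4-fluorobenzyl gives a 2.3-fold lower number from compound 1 to compound 4 (0.35 log units; beyond the scatter), the first step that isolates a change in one place. The step is modest, and it comes with no change in the counted features, since both groups carry 8 heavy atoms, one six-membered aromatic ring, no hydrogen-bond donors or acceptors and no net charge. Nothing on hand accounts for the step.

On these data alone, the swap removes the carbon link to the ring and replaces fluorine with two chlorines at once, so the share of each remains open. A 2,3-dichlorobenzyl group on the same nitrogen of compound 1 would separate the two, and an amine on that ring would test a different kind of substituent.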